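The compounds below may be only part of what the source reports. "The series", "measured", "known", "first", "only" and "open" are said of these compounds alone.

Compounds with measured values:

compound 1 `CCOC(=O)CN(Cc1ccccc1)c1nc(NCc2cccc(OC)c2)ncc1[N+](=O)[O-]`, 57400 nM
compound 2 `COC(=O)CN(C)c1nc(Nc2cccc(OC)c2)ncc1[N+](=O)[O-]`, 93700 nM
compound 3 `CCOC(=O)CNc1nc(NCc2ccccc2)ncc1[N+](=O)[O-]`, 52400 nM

All three were tested in a functional assay on MCF7 cells (Homo sapiens) for antiproliferative activity, read by MTT assay, with a stated time of 48 h; a higher number here means a weaker inhibitor, a lower number a stronger inhibitor. Among the three numbers, compound 1 stands second highest with 57400 nM. Its nearest neighbour is compound 3, whose 52400 nM lies within the usual scatter of it, and the furthest is compound 2, whose 93700 nM also lies within the scatter. The three values therefore describe a narrow band of weak activity, and no order among them can be read from these numbers.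

The unmeasured compound 4 `CCOC(=O)CN(Cc1ccccc1)c1nc(Nc2cccc(OC)c2)ncc1[N+](=O)[O-]` is reached from compound 1 by a single change: 3-methoxyphenyl in place of 3-methoxybenzyl on a nitrogen on an aromatic ring. The same change, cut one bond further out, reads as a (3-methoxybenzyl)amino group becoming a (3-methoxyphenyl)amino group. Within the data shown here, no pair of measured compounds isolates this step. Among the measured compounds shown here, compound 2 is the only measured compound that carries the 3-methoxyphenyl group on that nitrogen, and it stands within the scatter of compound 1, so the step is expected to be small. For compound 4 an estimate of 70000 nM is given, with a range from 30000 nM to 160000 nM. The expected step of a 1.2-fold higher number from compound 1 to compound 4 (0.09 log units; within the scatter) is thus not beyond the scatter, with at most a slight drift towards the higher number shown by compound 2.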

Compound 4, half-maximal inhibitory concentration: > 100000 nM
Compound 4 ended at the assay's limit (the forecaster's own chance of this, stated with the estimate: 15%); middle value at least 1.4-fold (0.15 log units) away from the limit.
By their numbers in this assay, from the lowest: compounds 3, 1 and 2 (each within the scatter of the next). At a limit, above all of these: compound 4.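

In this assay compound 4 gives > 100000 nM, which is a limit of the assay and not a number. Among these compounds, this gives the first direct reading of 3-methoxyphenyl in place of 3-methoxybenzyl on a nitrogen on an aromatic ring, an at least 1.7-fold higher number from compound 1 to compound 4 (0.24 log units; that floor lies within the scatter), and the change brings no lower number at this position, so a (3-methoxyphenyl)amino group offers no gain over the (3-methoxybenzyl)amino group on the core of compound 1. The floor of that step does not go beyond the scatter, and the true size of the step cannot be read, because the value of compound 4 is a limit: the limit of > 100000 nM in this assay, at which 1 of the 4 values shown sits.

On these data alone, it remains open whether a longer chain on the same nitrogen, such as a 2-(3-methoxyphenyl)ethyl group, would give a number different from that of compound 1, and whether the methoxy group itself matters, as a plain benzyl or a 3-hydroxybenzyl group at this place would show. Equally open, as far as these compounds go, is whether a carboxylic acid in place of the ester, or an amine in place of the nitro group, would move the number out of this weak range.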